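A Trifluoromethyl Step Tried Again on a Second Core

This account rests on a few compounds, and the source may have more. Where it says the series, first, only, none or still open, it means among the compounds named here.

The measurements here come from a functional assay on SW480 cells (Homo sapiens) for cytotoxicity, read by MTT assay, with a stated time of 4 days; on this read-out higher numbers stand for weaker inhibition and lower numbers for stronger inhibition. Compound 1 `Cc1ccc(S(=O)(=O)Oc2ccc3c(c2C)[C@H](Cn2cc(-c4ccccc4)nn2)[C@@]24CC(=O)[C@@](C)(CC[C@@H]32)C4)cc1` gives > 20000 nM in this assay, which is a limit of the assay rather than a number. Compound 2 `Cc1ccc(S(=O)(=O)Oc2ccc3c(c2C)[C@H](Cn2cc(-c4ccc(C(F)(F)F)cc4)nn2)[C@@]24CC(=O)[C@@](C)(CC[C@@H]32)C4)cc1` is compound 1 with one change, (trifluoromethyl in place of hydrogen on an aromatic carbon). In this assay compound 2 gives > 20000 nM, again a limit and not a number. The step that the two limits leave unreadable from compound 1 to compound 2 therefore cannot be sized, because both ends sit at the limit of > 20000 nM in this assay, at which 3 of the 3 values shown sit.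

Compound 3 `C=C1C[C@]23C[C@@]1(O)CC[C@H]2c1ccc(OS(=O)(=O)c2ccc(C)cc2)c(C)c1[C@@H]3Cn1cc(-c2ccccc2)nn1` carries the same atoms as compound 1, joined differently; the difference between the two cores is not broken down here. In this assay compound 3 gives > 20000 nM, which is a limit of the assay and not a number.

Compound 4 `C=C1C[C@]23C[C@@]1(O)CC[C@H]2c1ccc(OS(=O)(=O)c2ccc(C)cc2)c(C)c1[C@@H]3Cn1cc(-c2ccc(C(F)(F)F)cc2)nn1`, not yet measured, stands to compound 3 as compound 2 stands to compound 1: the change is trifluoromethyl in place of hydrogen on an aromatic carbon, and the place of the change is described in the same words for both pairs, so it is the same change made on a second core.

Since the step between compound 1 and compound 2 in this assay could not be read, the expected step that the limit leaves unreadable from compound 3 to compound 4 rests only on the fact that all three measured values sit at the limit of > 20000 nM in this assay, at which 3 of the 3 values shown sit. The value of compound 4 in this assay is estimated at 25000 nM. For compound 4 the expected range runs from 8000 nM to 60000 nM.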

Compound 4, half-maximal inhibitory concentration: > 20000 nM
Compound 4: no number, only a limit (the forecaster's own chance of this, stated with the estimate: 85%); the middle value is on the limit's open side.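

In this assay compound 4 gives > 20000 nM, which is a limit of the assay and not a number. No size can be read for the step from compound 3 to compound 4, because both ends sit at a limit: the limit of > 20000 nM in this assay, at which 4 of the 4 values shown sit. The compounds shown leave open whether trifluoromethyl in place of hydrogen on an aromatic carbon changes the read-out on either core.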